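A few compounds are considered here, and "the series" means these few. Any claim that something is new, unique, unknown or untested is made for them only; others in the source may bear on it.

Measured so far:
compound 1 `CC(C)C[C@H](N)c1cc(C(F)(F)F)ccc1N1CCN(C(=O)CCC2CCCCC2)CC1` — 5700 nM
compound 2 `CC(C)C[C@H](N)c1cc(C(F)(F)F)ccc1N1CCN(C(=O)CSc2ccc(Cl)cc2Cl)CC1` — 1500 nM

For the measured compounds named here, in an assay on HEK293 cells for displacement of a labelled ligand from Melanocortin receptor 4 (Homo sapiens) (a lower number here means a stronger inhibitor, a higher number a weaker inhibitor), compound 1 gives the higher of these two numbers; the one measured step away from it is a 3.8-fold lower number from compound 1 to compound 2 (0.58 log units; beyond the scatter), a modest move to a stronger inhibitor. Compound 3 `Cc1ccc(OCC(=O)N2CCN(c3ccc(C(F)(F)F)cc3[C@@H](N)CC(C)C)CC2)c(C)c1` is not yet measured. Its change from compound 1 is 2,4-dimethylphenoxy in place of cyclohexylmethyl on a saturated chain carbon bound to a carbonyl carbon. This resembles the step from compound 1 to compound 2, where a non-aromatic ring also gave way to an aromatic one at the same place, so a gain of similar or somewhat smaller size is expected. Compound 3 is therefore estimated at 2500 nM, between 800 nM and 8000 nM, meaning a 2.3-fold lower number from compound 1 to compound 3 (0.36 log units; beyond the scatter).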

Compound 3, inhibition constant: 4000 nM
For compound 3 the middle estimate is 1.6-fold (0.20 log units) below the measured one; measured number inside the range.
By their numbers in this assay, from the lowest: compound 2; then compounds 3 and 1 (each within the scatter of the next).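

In this assay, 2,4-dimethylphenoxy in place of cyclohexylmethyl gives a 1.4-fold lower number from compound 1 to compound 3 (0.15 log units; within the scatter), which means an aromatic ring at this place brings no clear gain by itself. Replacing (2,4-dichlorophenyl)sulfanyl with 2,4-dimethylphenoxy gives a 2.7-fold higher number from compound 2 to compound 3 (0.43 log units; beyond the scatter), which shows that these two aromatic groups are not interchangeable here. Nothing available explains this difference. Still open, from the compounds shown here alone, is whether the sulfur link or the two chlorines matter more, as the link and the ring substituents change together in these compounds. A 2,4-dichlorophenoxy group at the same place would separate the two.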